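The source may hold more compounds than are shown below. What is called first, only, known or untested is meant among the compounds shown, and "the series" means these compounds.

Of the compounds shown here, three built on one shared core have been tested in an assay on isolated protein for inhibition of activin receptor type-2A (Homo sapiens), read by 33P incorporation, with a stated time of 20 min, in the presence of a further agent that is not named here; on this read-out higher numbers stand for weaker inhibition and lower numbers for stronger inhibition. Compound 1 `COc1cn2ncc(-c3ccnc(OC(C)(C)C)c3)c2nc1-c1cnn(C)c1` gives 800 nM in this assay. Compound 2 `CNc1nc2c(-c3ccnc(OC)c3)cnn2cc1C1CC1` gives 630 nM. Compound 3 `COc1cc(-c2cnn3cc(OC)c(C4CCCC4)nc23)ccn1` gives 2900 nM, the highest of the three numbers; its gap to compound 1 and its gap to compound 2 both lie beyond the usual scatter, so compound 3 is the weakest inhibitor among those measured. For the measured compounds named here, no two of these three compounds differ in only one place, so no single structural step between measured compounds can be read off, and nothing in the measured set isolates the effect of any one group.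

Compound 4 `CCc1nc2c(-c3ccnc(OC)c3)cnn2cc1OC` has not yet been measured. It differs from compound 3 in one place: ethyl in place of cyclopentyl on an aromatic carbon. Going by the values given here, the only guidance is that compound 3, the sole compound with a cyclopentyl group, sits at the top of the numbers, while compounds 1 and 2, with different substitution, sit lower; the expectation is therefore a step of a 2.4-fold lower number from compound 3 to compound 4 (0.38 log units; beyond the scatter) that is downward and near the edge of the scatter. Compound 4 is expected to give about 1200 nM in this assay, with a likely range from 400 nM to 3500 nM.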

Compound 4, half-maximal inhibitory concentration: 960 nM
Compound 4: the middle estimate sits 1.3-fold (0.10 log units) above what was measured, and the stated range covers the measured number.
By their numbers in this assay, from the lowest: compounds 2, 1 and 4 (each within the scatter of the next); then compound 3.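

In this assay, for the compounds shown here, putting ethyl in place of cyclopentyl on the aromatic carbon next to the ring nitrogen gives a 3.0-fold lower number from compound 3 to compound 4 (0.48 log units; beyond the scatter), the first step in this set that changes a single group, and it lies beyond the usual scatter. This shows that the number responds to what sits at this position, and that a ring of carbon is not needed here for inhibition: ethyl, with 2 heavy atoms and no ring, goes with stronger inhibition than cyclopentyl, with 5 heavy atoms. No measurement shown here speaks to what lies behind this step.

From the compounds shown here alone, whether the number would keep falling with methyl, or rise again with a longer chain such as propyl, stays open, as does the effect of an amine or a carboxylic acid on this carbon. Going by these compounds, this is also a single pair with a methoxy group on the neighbouring ring carbon, so whether the same change gives a similar step on a different background remains unknown.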